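A few compounds are considered here, and "the series" means these few. Any claim that something is new, unique, unknown or untested is made for them only; others in the source may bear on it.

Within the data shown here, in a functional assay on MIA PaCa-2 cells (Homo sapiens) for inhibition, read by MTT assay (a higher number here means a weaker inhibitor, a lower number a stronger inhibitor), compound 1 `O=C(Nc1ccccc1)c1cc2cnc(Nc3ccc(N4CCNCC4)cn3)nc2n1C1CCCC1` gives 2800 nM and compound 2 `O=C(Nc1ccccc1)c1cc2cnc(Nc3ccc(N4CCNCC4)cn3)nc2n1Cc1ccccc1` gives 3600 nM, so compound 2 stands within the scatter of its only neighbour. Compound 3 `CN(C)C(=O)c1cc2cnc(Nc3ccc(N4CCNCC4)cn3)nc2n1Cc1ccccc1` keeps the benzyl of compound 2 and changes the amide: dimethylamino in place of anilino on a carbonyl carbon. Among the measured compounds shown here, the one measured step, a 1.3-fold higher number from compound 1 to compound 2 (0.11 log units; within the scatter), lies at the aromatic nitrogen and says nothing directly about this change. With no measured guide to direction, the expected step is a 1.2-fold lower number from compound 2 to compound 3 (0.08 log units; within the scatter), none beyond the scatter. The estimate for compound 3 is 3000 nM, with an expected range of 800 nM to 10000 nM.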

Compound 3, half-maximal inhibitory concentration: 30400 nM
For compound 3 the middle estimate is 10-fold (1.01 log units) below the measured one; the measured number lies above the stated range.
By their numbers in this assay, from the lowest: compounds 1 and 2 (each within the scatter of the next); then compound 3.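

At this carbonyl carbon, phenylcarbamoyl to dimethylcarbamoyl gives the only step shown that lies beyond the scatter, with an 8.4-fold higher number from compound 2 to compound 3 (0.93 log units; beyond the scatter). The aromatic ring and the amide hydrogen of anilino leave together, so this pair cannot separate the two. No measured evidence bears on the reason for this step. Open, going by these compounds, is whether methylamino, which keeps the amide hydrogen without the ring, or piperidin-1-yl, which has a ring but no amide hydrogen, would stay nearer compound 2. Also open, on these data alone, is whether the same step holds with cyclopentyl on the aromatic nitrogen.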